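Nitro in place of bromo: notes before measurement

The compounds below may be only part of what the source reports. "The series", "measured", "known", "first", "only" and "open" are said of these compounds alone.

Going by the values given here, in a functional assay on PC-3 cells (Homo sapiens) for antiproliferative activity, read by MTT assay, with a stated time of 72 h, tested at 5 uM (on this read-out lower numbers stand for less inhibition and higher numbers for more inhibition at the one concentration tested (going by the name of the read-out)), compound 1 `CCOC(=O)/C(C#N)=C(/NNC(=O)c1cc(OC)c(OC)c(OC)c1)N[C@H](C)c1ccccc1` gives 32.1%, while compound 3 `CCOC(=O)/C(C#N)=C(/NNC(=O)c1cc(OC)c(OC)c(OC)c1)N[C@@H](C)c1ccccc1` gives 3.2%; the step of a number 28.9 percentage points lower from compound 1 to compound 3 (beyond the scatter) is the only measured step in the set, and its sole structural basis is the fact that compounds 1 and 3 differ only in the configuration as drawn. Compound 2 `CCOC(=O)/C(C#N)=C(/Nc1ccc(Br)cc1)N[C@H](C)c1ccccc1` gives 1.5% in this assay, a number that sits together with compound 3 and well below compound 1. Compound 4 `CCOC(=O)/C(C#N)=C(/Nc1ccc([N+](=O)[O-])cc1)N[C@H](C)c1ccccc1` differs from compound 2 by nitro in place of bromo on an aromatic carbon. Among the compounds with values here, no measured step exchanges one aromatic substituent for another, so the configurational step offers no guide to this change, and no shift beyond the scatter is expected. The step of a number 3.5 percentage points higher from compound 2 to compound 4 (within the scatter) is therefore estimated to stay within the scatter. Compound 4 is expected to give about 5% in this assay, between 0% and 18%.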

Compound 4, a percentage reported as inhibition, at one concentration (the size of the read-out at that concentration, not a potency): 2.9%
Compound 4: the middle estimate sits 2.1 percentage points above what was measured; the range from low to high includes it.
By their numbers in this assay, from the lowest: compounds 2, 4 and 3 (each within the scatter of the next); then compound 1.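

In this assay, going by these compounds alone, the change from 4-bromophenyl to 4-nitrophenyl gives a number 1.4 percentage points higher from compound 2 to compound 4 (within the scatter), the first measured exchange on this aromatic carbon. At this position, then, nitro and bromo give the same reading within the scatter, and neither lifts the number clear of the other. Nothing in the evidence bears on this exchange.

As far as these compounds go, whether an amine or a carboxylic acid on this carbon would move the number remains open. Also open, from the compounds shown here alone, is whether inverting the stereocentre of compound 2 or compound 4 would produce a step like a number 28.9 percentage points lower from compound 1 to compound 3 (beyond the scatter).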